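The source may report more compounds than this note shows. Statements on the series, on what has been measured and on what is new or still open speak of the compounds shown alone.

Measured so far:
Compound 1 `CO/N=c1\[nH]cnc2c1[n+](C/C=C(\C)CC/C=C(/C)CCC=C(C)C)cn2C` — 28700 nM
Compound 2 `CC(C)=CCC/C(C)=C\CC/C(C)=C/C[n+]1cn(C)c2nc[nH]/c(=N\OCc3ccccc3)c21` — 25200 nM
Compound 3 `CO/N=c1\[nH]cnc2c1[n+](C/C=C(\C)CC/C=C(\C)CC/C=C(\C)CCC=C(C)C)cn2CCC#N` — 11400 nM

All three numbers come from a functional assay on ACHN cells (Homo sapiens) for cytotoxicity; on this read-out lower numbers stand for stronger inhibition and higher numbers for weaker inhibition. Compound 2 arises from compound 1 by a single change, (phenyl in place of hydrogen on a saturated chain carbon bound to an oxygen). The step reads a 1.1-fold lower number from compound 1 to compound 2 (0.06 log units; within the scatter). Compound 3 gives the lowest of the three numbers; the difference between its core and the core of compound 1 is not broken down here.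

Compound 4 `CC(C)=CCC/C(C)=C/CC/C(C)=C/CC/C(C)=C/C[n+]1cn(CCC#N)c2nc[nH]/c(=N\OCc3ccccc3)c21` is not yet measured. Going by the values given here, it arises from compound 3 by phenyl in place of hydrogen on a saturated chain carbon bound to an oxygen, which is the same change, at the same place, as the one from compound 1 to compound 2. For compound 4 a step of about a 1.1-fold lower number from compound 3 to compound 4 (0.06 log units; within the scatter) is expected, because the earlier step of a 1.1-fold lower number from compound 1 to compound 2 (0.06 log units; within the scatter) stayed within the scatter. Compound 4 in this assay is therefore estimated at 10000 nM, with a range from 5000 nM to 20000 nM.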

Compound 4, half-maximal inhibitory concentration: 38900 nM
Estimate against measurement, compound 4: 3.9-fold (0.59 log units) below, outside the stated range (above it).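

In this assay, the change from methoxy to benzyloxy does not carry over unchanged from one core to the other, and the two steps differ: the same change on two cores in this assay, a 1.1-fold lower number (0.06 log units; within the scatter) from compound 1 to compound 2 and a 3.4-fold higher number (0.53 log units; beyond the scatter) from compound 3 to compound 4, 3.9-fold (0.59 log units) apart, beyond the scatter of two such steps. On the core of compound 3 the phenyl weakens inhibition, with a 3.4-fold higher number from compound 3 to compound 4 (0.53 log units; beyond the scatter), so a flat result on the core of compound 1 is no safe guide to other cores in this series. The two cores differ in more than one place, so these steps do not show which difference matters, and two pairs establish no general rule.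

Still open, on these data alone, is how an ethoxy or a phenethyloxy group would read on each core. Also open, as far as these compounds go, is whether the nitrile or the longer chain alone reproduces the larger step.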